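The source may report more compounds than this note shows. Statements on the series, on what has been measured and on what is new or still open speak of the compounds shown alone.

Compound 1 `CCC[C@@H](OC(C)=O)C1=C(Br)[C@@](C)(OC)OC1=O` is the reference point of this small series. Among the compounds with values here, in a functional assay on ZR-75-1 cells (Homo sapiens) for cytotoxicity (a higher number here means that more compound is needed for the effect, a lower number that less compound is needed), compound 1 gives 2.4 ug/mL, the lowest of the three numbers measured so far. Compound 2 `CCC[C@@H](OC(C)=O)C1=C(Br)[C@@](CI)(OC)OC1=O` gives 7.9 ug/mL and compound 3 `CCC[C@@H](OC(C)=O)C1=C(Br)[C@](OC)(C(Br)Br)OC1=O` gives 3.8 ug/mL in this assay. The measured steps are a 3.3-fold higher number from compound 1 to compound 2 (0.52 log units; beyond the scatter), a 1.6-fold higher number from compound 1 to compound 3 (0.20 log units; within the scatter) and a 2.1-fold lower number from compound 2 to compound 3 (0.32 log units; beyond the scatter); each of them replaces one group by another on or at the saturated ring carbon of the shared core.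

Compound 4 `CCC[C@@H](OC(C)=O)C1=C(Br)[C@](C)(OC)OC1=O` differs from compound 1 as follows: the two compounds have the same atoms and bonds and differ only in configuration as drawn: 1 of 2 stereo elements differ; a stereocentre at a saturated ring carbon is drawn S in compound 1 and R in compound 4. Within the data shown here, none of the measured steps bears on this change; all three alter a substituent rather than the configuration at the saturated ring carbon, so there is no precedent for how this assay responds to inverting that centre. Among the measured compounds shown here, the only guide is that the three numbers so far span a modest range. For the measured compounds named here, with no step that speaks to the change, no shift beyond the scatter is expected in either direction, but the uncertainty around that expectation is wider than for a substituent swap. Compound 4 is therefore estimated at 3.2 ug/mL in this assay, within 1.2 ug/mL to 10 ug/mL, corresponding to an expected step of a 1.3-fold higher number from compound 1 to compound 4 (0.12 log units; within the scatter).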

Compound 4, concentration for half-maximal effect: 4 ug/mL
Beside the measured number, compound 4's estimate is 1.3-fold (0.10 log units) below it, within the range that was stated.
By their numbers in this assay, from the lowest: compounds 1, 3, 4 and 2 (each within the scatter of the next, the first and the last beyond it).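

In this assay, inverting the stereocentre at the saturated ring carbon, with the methyl and methoxy groups kept in place, gives a 1.7-fold higher number from compound 1 to compound 4 (0.22 log units; within the scatter). Within the data shown here, this is the first step that tests configuration rather than a substituent, and at this position, with methyl as the substituent, the assay does not separate the S and R forms. The step can be assigned to that single stereocentre, because no other structural feature changes: the fact that compounds 1 and 4 differ only in the configuration as drawn

It remains open whether the same holds when iodomethyl or dibromomethyl occupies that carbon, since the compounds shown give no matched pair of configurations for either group, and the second stereo element is not varied in any of them. Also open, on these data alone, is how this assay responds when the methoxy group gives way to a free hydroxyl or an amine, or when the acetate gives way to a longer chain ester.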